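The source may report more compounds than this note shows. Statements on the series, on what has been measured and on what is new or still open speak of the compounds shown alone.

Compound 3 `COc1cccc(-c2c(C)n(Cc3c(F)cccc3F)c(=O)n(C[C@H](N)CC(C)C)c2=O)c1F` gives the lowest number of the three measured in an assay on HEK293 cells for binding affinity to Gonadotropin-releasing hormone receptor (Homo sapiens), read by radioligand binding (a lower number here means a stronger inhibitor, a higher number a weaker inhibitor), with 6.4 nM. Compound 1 `COc1cccc(-c2c(C)n(Cc3c(F)cccc3F)c(=O)n(C[C@@H](N)C3CCCC3)c2=O)c1F` gives 94 nM in this assay, and compound 2 `COc1cccc(-c2c(C)n(Cc3c(F)cccc3F)c(=O)n(C[C@H](NC(C)C)C3CCCCC3)c2=O)c1F` gives 23 nM. The steps of a 15-fold lower number from compound 1 to compound 3 (1.17 log units; beyond the scatter) and a 3.6-fold lower number from compound 2 to compound 3 (0.56 log units; beyond the scatter) both run toward the open-chain amine, while a 4.1-fold lower number from compound 1 to compound 2 (0.61 log units; beyond the scatter) is smaller. Compound 4 `COc1cccc(-c2c(C)n(Cc3c(F)cccc3F)c(=O)n(C[C@H](N)C(C)C)c2=O)c1F` differs from compound 3 by isopropyl in place of isobutyl on a saturated chain carbon bound to an amine nitrogen and a saturated chain carbon. Going by the values given here, no measured pair makes a change of this kind, so the steps above bear on it only loosely. The change is small, and a step within the scatter, or at most a modest rise, is expected for a 1.6-fold higher number from compound 3 to compound 4 (0.19 log units; within the scatter). Compound 4 is therefore estimated at 10 nM in this assay, within 4 nM to 30 nM.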

Compound 4, inhibition constant: 51 nM
The estimate for compound 4 lay 5.1-fold (0.71 log units) below the measured number; measured number above the stated range.
By their numbers in this assay, from the lowest: compound 3; then compound 2; then compounds 4 and 1 (each within the scatter of the next).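

Replacing isobutyl with isopropyl on a saturated chain carbon bound to an amine nitrogen and a saturated chain carbon is not a neutral trim: this assay shows an 8.0-fold higher number from compound 3 to compound 4 (0.90 log units; beyond the scatter), so this position responds to the chain itself. An open chain alone does not secure the low number, as a 2.2-fold higher number from compound 2 to compound 4 (0.35 log units; beyond the scatter) and a 1.8-fold lower number from compound 1 to compound 4 (0.27 log units; within the scatter) show. Nothing available here explains the drop. Going by these compounds, whether a longer chain such as n-pentyl, or a tert-butyl group, would hold the number of compound 3 remains open.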